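The compounds below may be only part of what the source reports. "The series", "measured", "known", "first", "only" and "open" are said of these compounds alone.

Compound 3 `C[C@@H]1CCCN1c1c(C#N)c2c(N)nc(Nc3cn(C)nc3Cl)nc2n1C` gives 34 nM in an assay on isolated protein for inhibition of Leucine-rich repeat serine/threonine-protein kinase 2 (Homo sapiens), read by TR-FRET and LanthaScreen, with stated times of 50 min and 30 min, in the presence of a further agent that is not named here; on this read-out lower numbers stand for stronger inhibition and higher numbers for weaker inhibition. Compound 2 `Cc1nn(C2COC2)cc1Nc1nc(N)c2c(C#N)c(N3CCC[C@H]3C)n(C)c2n1` in this assay gives 38 nM, and compound 1 `Cc1c(Nc2nc(N)c3c(C#N)c(N4CCC[C@H]4C)n(C)c3n2)cnn1C` gives 75 nM; the step of a 1.1-fold lower number from compound 2 to compound 3 (0.05 log units; within the scatter) stays within the scatter, while a 2.2-fold lower number from compound 1 to compound 3 (0.34 log units; beyond the scatter) goes beyond it. The step to compound 4 `C[C@@H]1CCCN1c1c(C#N)c2c(N)nc(N)nc2n1C` is hydrogen in place of 3-chloro-1-methyl-1H-pyrazol-4-yl on a nitrogen on an aromatic ring. For the measured compounds named here, none of the measured steps touches this change: a 2.0-fold lower number from compound 1 to compound 2 (0.30 log units; within the scatter), a 2.2-fold lower number from compound 1 to compound 3 (0.34 log units; beyond the scatter) and a 1.1-fold lower number from compound 2 to compound 3 (0.05 log units; within the scatter) all exchange one substituted pyrazolyl for another and stay modest, so they give no direct guide to removing the group altogether. Since the whole group leaves, a rise in the number much larger than those steps is expected, an 88-fold higher number from compound 3 to compound 4 (1.95 log units; beyond the scatter). Compound 4 is therefore estimated at 3000 nM, with a range from 400 nM to 30000 nM.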

Compound 4, half-maximal inhibitory concentration: 248 nM
Compound 4: the middle estimate sits 12-fold (1.08 log units) above what was measured; measured number outside the range, below it.
By their numbers in this assay, from the lowest: compounds 3, 2 and 1 (each within the scatter of the next, the first and the last beyond it); then compound 4.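

In this assay, taking the whole substituted pyrazolyl off this nitrogen gives a 7.3-fold higher number from compound 3 to compound 4 (0.86 log units; beyond the scatter) and a 6.5-fold higher number from compound 2 to compound 4 (0.81 log units; beyond the scatter) and a 3.3-fold higher number from compound 1 to compound 4 (0.52 log units; beyond the scatter) in the three comparisons. Each pyrazolyl therefore gives a lower number than hydrogen, yet the step stays modest for the loss of an entire group. Nothing given here explains the size of this step. As far as these compounds go, it remains open whether a single methyl or an acetyl on this nitrogen would give numbers nearer those of the pyrazolyl compounds. A phenyl ring in place of the pyrazolyl is equally untested among the compounds shown.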